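A few compounds are considered here, and "the series" means these few. Any claim that something is new, unique, unknown or untested is made for them only; others in the source may bear on it.

Notes on the series. Compound 3 `COc1ccc(-n2cc(COC(=O)c3cc4ccccc4[nH]3)nn2)cc1` gives 16200 nM in a functional assay on MCF7 cells (Homo sapiens) for cytotoxicity, read by MTT assay, with a stated time of 48 h; a lower number here means a stronger inhibitor, a higher number a weaker inhibitor. Compound 1 `Cc1cccc(-n2cc(COC(=O)c3cc4ccccc4[nH]3)nn2)c1C` gives 17100 nM and compound 2 `Cc1cc(C)cc(-n2cc(COC(=O)c3cc4ccccc4[nH]3)nn2)c1` gives 30500 nM in this assay; the steps of a 1.1-fold lower number from compound 1 to compound 3 (0.02 log units; within the scatter) and a 1.9-fold lower number from compound 2 to compound 3 (0.27 log units; within the scatter), like a 1.8-fold higher number from compound 1 to compound 2 (0.25 log units; within the scatter), stay within the scatter, so compound 3 stands apart from neither. Compound 4 `O=C(OCc1cn(-c2ccccc2Br)nn1)c1cc2ccccc2[nH]1` carries the change (2-bromophenyl in place of 4-methoxyphenyl on an aromatic nitrogen). The three measured steps all exchange the group on that aromatic nitrogen and none moved this assay beyond the scatter, so from compound 3 to compound 4 no step beyond the scatter is expected in either direction, a 1.1-fold higher number from compound 3 to compound 4 (0.05 log units; within the scatter). Compound 4 is therefore estimated at 18000 nM, with a range from 7000 nM to 45000 nM.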

Compound 4, half-maximal inhibitory concentration: 38800 nM
Compound 4: middle estimate off by 2.2-fold (0.33 log units), on the low side; low and high end bracket the measured number.
By their numbers in this assay, from the lowest: compounds 3, 1, 2 and 4 (each within the scatter of the next, the first and the last beyond it).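

In this assay, within the data shown here, the group on the aromatic nitrogen can, unlike in the earlier steps, move the number beyond the scatter, with a 2.4-fold higher number from compound 3 to compound 4 (0.38 log units; beyond the scatter) and a 2.3-fold higher number from compound 1 to compound 4 (0.36 log units; beyond the scatter) as modest steps, while a 1.3-fold higher number from compound 2 to compound 4 (0.10 log units; within the scatter) stays within it. The 2-bromophenyl group therefore stands apart from 4-methoxyphenyl and 2,3-dimethylphenyl but not from 3,5-dimethylphenyl. No supporting measurement bears on these steps.

Open, on these data alone, is whether an amine or a carboxylic acid on that phenyl ring would bring the number below those of compound 3 and compound 1. Also open, as far as these compounds go, is whether the bromine itself or where it sits sets compound 4 apart.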